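Fluoro in Place of Methyl: Compound 1 to Compound 4

The source may report more compounds than this note shows. Statements on the series, on what has been measured and on what is new or still open speak of the compounds shown alone.

Compound 1 `CCN1CCN(c2cc(C)c3cc(NC(=O)c4cccc(C)c4)ccc3n2)CC1` holds the second-highest of the three numbers in a functional assay on SK-BR-3 cells (Homo sapiens) for antiproliferative activity, read by MTT assay, with a stated time of 72 h (on this read-out higher numbers stand for weaker inhibition and lower numbers for stronger inhibition), where compound 1 gives 13700 nM. Compound 3 `Cc1cc(N2CCN(C(C)C)CC2)nc2ccc(NC(=O)c3ccc(Cl)c(Cl)c3)cc12` gives 6680 nM, a lower number beyond the scatter, while compound 2 `Cc1cc(N2CCCC2)nc2ccc(NC(=O)c3ccc(Cl)c(Cl)c3)cc12` gives 43400 nM, a higher number beyond the scatter. Compound 4 `CCN1CCN(c2cc(C)c3cc(NC(=O)c4cccc(F)c4)ccc3n2)CC1` differs from compound 1 in one place: fluoro in place of methyl on an aromatic carbon. Going by the values given here, the only measured step, a 6.5-fold lower number from compound 2 to compound 3 (0.81 log units; beyond the scatter), alters the group on the shared core rather than the 3-methylphenyl, so no measured step bears on the present change. The expected step in this assay is therefore a 1.0-fold higher number from compound 1 to compound 4 (0.01 log units; within the scatter), within the scatter and with no clear direction. Compound 4 is estimated at 14000 nM, between 6000 nM and 35000 nM.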

Compound 4, half-maximal inhibitory concentration: 24900 nM
Estimate against measurement, compound 4: 1.8-fold (0.25 log units) below; measured number inside the range.
By their numbers in this assay, from the lowest: compound 3; then compounds 1, 4 and 2 (each within the scatter of the next, the first and the last beyond it).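

Going by these compounds alone, this is the first measured change on the 3-methylphenyl rather than on the group at the other end of the shared core. In this assay, a 1.8-fold higher number from compound 1 to compound 4 (0.26 log units; within the scatter) stays within the scatter, so 3-fluorophenyl and 3-methylphenyl cannot be told apart here. Nothing shown gives a reason for this result. As far as these compounds go, it remains open whether methoxy, trifluoromethyl or an amine at this place would give a step beyond the scatter. Also open, from the compounds shown here alone, is whether fluoro in place of methyl reads the same alongside 4-isopropylpiperazin-1-yl.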